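The compounds below may be only part of what the source reports. "The series", "measured", "known", "first", "only" and "open" are said of these compounds alone.

Measured so far:

Compound 1, `N#Cc1ccccc1CN1CCc2c(sc(NC(=O)c3ccccc3Cl)c2C(N)=O)C1`: in a functional assay on HeLa cells (Homo sapiens) for antiproliferative activity, with a stated time of 24 h (on this read-out lower numbers stand for stronger inhibition and higher numbers for weaker inhibition), compound 1 reaches only the limit > 50000 nM.
Compound 2, `NC(=O)c1c(NC(=O)c2ccccc2Cl)sc2c1CCN(C(=S)Nc1ccccc1F)C2`: in this assay compound 2 gives 28700 nM.
Compound 3, `NC(=O)c1c(NC(=O)c2ccccc2Cl)sc2c1CCN(C(=S)Nc1ccc(C(F)(F)F)cc1)C2`: in this assay compound 3 reaches only the limit > 50000 nM.

Compound 3 therefore stands at the top of the range shown, where no number was obtained, and it shares that position with compound 1 (the limit of > 50000 nM in this assay, at which 2 of the 3 values shown sit). The two steps measured so far both touch the limit: an at least 1.7-fold lower number from compound 1 to compound 2 (0.24 log units; that floor lies within the scatter), and an at least 1.7-fold higher number from compound 2 to compound 3 (0.24 log units; that floor lies within the scatter). Neither step is large enough to be trusted as a real change.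

Compound 4, `NC(=O)c1c(NC(=O)c2ccccc2Cl)sc2c1CCN(C(=S)Nc1cccnc1)C2`, differs from compound 3 by pyridin-3-yl in place of 4-(trifluoromethyl)phenyl on an amide-type nitrogen. Going by the values given here, the closest precedent is the step from compound 2 to compound 3, which also exchanged one aryl group on the thiourea nitrogen for another and stayed within the scatter. Among the compounds with values here, with only one numbered value among three and no trend to lean on, the expected outcome for compound 4 is a value close to where compound 3 sits, with the step of an at least 1.2-fold lower number from compound 3 to compound 4 (0.09 log units; that floor lies within the scatter) expected to stay within the scatter, and compound 4 is estimated at 40000 nM, in the range 15000 nM to 100000 nM.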

Compound 4, half-maximal inhibitory concentration: > 50000 nM
Compound 4 was reported as a limit; the forecaster's own chance of this, stated with the estimate: 55%; middle value at least 1.2-fold (0.09 log units) away from the limit.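

Compound 4 is one more compound that gives no number in this assay, only a limit: the limit of > 50000 nM in this assay, at which 3 of the 4 values shown sit. So on this amide-type nitrogen, pyridin-3-yl, which is smaller than 4-(trifluoromethyl)phenyl by heavy-atom count and brings a ring nitrogen and a hydrogen-bond acceptor, also fails to give a readable value. Going by these compounds alone, the one readable step is an at least 1.7-fold higher number from compound 2 to compound 4 (0.24 log units; that floor lies within the scatter), so it cannot be taken as a real change, and the steps joining two limits cannot be read at all.

Within the data shown here, with compound 2 the only compound with a number, no ranking of these aryl groups is possible. From the compounds shown here alone, it remains open whether a plain alkyl chain, or a phenyl ring carrying a carboxylic acid or an amine, on this nitrogen would give a clearly lower number.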